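Allyl series: replacing the bromofluorophenyl arm of compound 2

This account rests on a few compounds, and the source may have more. Where it says the series, first, only, none or still open, it means among the compounds named here.

Measured compounds in a functional assay on Huh-7 cells (Homo sapiens) for cytotoxicity, read by CCK-8 assay, with a stated time of 72 h; on this read-out lower numbers stand for stronger inhibition and higher numbers for weaker inhibition:
compound 1 `COc1ccccc1/C=c1\c(=O)[nH]/c(=C/c2ccccc2Cl)c(=O)n1C`, 300 nM
compound 2 `C=CCn1c(=O)/c(=C\c2ccc(F)c(Br)c2)[nH]c(=O)/c1=C\c1ccccc1OC`, "not active" (no number reported)
compound 3 `C=CCn1c(=O)/c(=C\c2cccc(Br)c2)[nH]c(=O)/c1=C\c1cccc(Br)c1`, "not active" (no number reported)

Going by the values given here, compound 1 is the only member with a number in this assay; for compound 1 that number is 300 nM. Compound 2 stands without a single number, reported as "not active" (no number reported), and compound 3 shares that position, also reported as "not active" (no number reported). No pair of these compounds differs in one place only, so no step between measured compounds can be stated.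

The next compound, compound 4 `C=CCn1c(=O)/c(=C\c2ccccc2C(F)(F)F)[nH]c(=O)/c1=C\c1ccccc1OC`, carries the change (2-(trifluoromethyl)phenyl in place of 3-bromo-4-fluorophenyl on a double-bonded chain carbon bound to an aromatic carbon). The rest of the shared core of compound 2 is kept.

Without a measured step of this kind, the size of the step in this assay cannot be taken from the data. Compound 2 gave no number in this assay, and compound 3, with a different arm in the same place, gave none either, so the step from compound 2 to compound 4 is expected to leave the read-out close to where compound 2 stands, possibly again without a number.

For compound 4 the half-maximal inhibitory concentration in this assay is estimated at 10000 nM, with a range from 1000 nM to 100000 nM.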

Compound 4, half-maximal inhibitory concentration: 9500 nM
Compound 4: the middle estimate sits 1.1-fold (0.02 log units) above what was measured, and the stated range covers the measured number.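

No new step can be read: in this assay compound 4 gives 9500 nM as a number, but compound 2, its one-place partner, has none. The compounds shown leave open how far a single change of arm on the shared core moves this read-out. No measured evidence bears on this result.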